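This account rests on a few compounds, and the source may have more. Where it says the series, first, only, none or still open, it means among the compounds named here.

Compound 1, `CNc1nc(NCc2ccc(S(C)(=O)=O)cc2)cc(-c2ccccn2)n1`, gives 185 nM in a functional assay on HEK293 cells for agonist activity at G-protein coupled receptor 39 (Mus musculus), read by inositol phosphate accumulation; a higher number here means that more compound is needed for the effect, a lower number that less compound is needed.
Compound 2, `CNc1nc(NCC(C)(C)C)cc(-c2ccccn2)n1`, gives 365 nM.
Compound 3, `CNc1nc(NCc2ccc(NS(C)(=O)=O)cc2)cc(-c2ccccn2)n1`, gives 8 nM.

Among these three, compound 2 gives the highest number; its gap to compound 1 lies within the scatter, while compound 3 sits far lower. Compound 4, `CNc1nc(NCC2CC2)cc(-c2ccccn2)n1`, is compound 2 with cyclopropyl in place of tert-butyl on a saturated chain carbon bound to a nitrogen on an aromatic ring. Among the compounds with values here, the only measured step, a 23-fold lower number from compound 1 to compound 3 (1.36 log units; beyond the scatter), changes a different part of the molecule and so does not bear on this exchange; no measured pair differs at that place. With no guide from the measured steps, only a small change is expected: a 1.1-fold higher number from compound 2 to compound 4 (0.04 log units; within the scatter) is estimated to stay within the scatter. Compound 4 is therefore expected to give about 400 nM, in a range from 150 nM to 1200 nM.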

Compound 4, half-maximal effective concentration: 115 nM
The estimate for compound 4 lay 3.5-fold (0.54 log units) above the measured number, and the stated range ends above it.
By their numbers in this assay, from the lowest: compound 3; then compounds 4, 1 and 2 (each within the scatter of the next, the first and the last beyond it).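

Within the data shown here, at this place, on a saturated chain carbon bound to a nitrogen on an aromatic ring, the earlier compounds offered no measured step. Cyclopropyl in place of tert-butyl now gives a 3.2-fold lower number from compound 2 to compound 4 (0.50 log units; beyond the scatter) in this assay and so shows that the number does respond to the group held here, even with the rest of the molecule unchanged. No measurement available here explains this shift.

Going by these compounds, whether the gain comes from the three-membered ring itself remains open, since only these two groups can be compared here. A cyclobutyl group, an isopropyl group or a longer chain such as n-butyl could help to settle that.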